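The compounds below may be only part of what the source reports. "The series", "measured", "known", "first", "only" and "open" are said of these compounds alone.

Going by the values given here, in an ADME assay for permeability, read by LC-MS, using PAMPA, with a stated time of 3 h (a higher number here means that the compound crosses the layer faster, a lower number that the compound crosses the layer more slowly), compound 2 (`N#Cc1ccc(N[C@H]2CC[C@H](N(C(=O)NCc3ccccc3)c3ccc(-c4cccnc4)cc3)CC2)nc1`) gives 280 nm/s as the only number, so it cannot be ranked against any other compound. Compound 1 (`N#Cc1ccc(N[C@H]2CC[C@H](N(C(=O)NCc3ccccc3)c3ccccc3)CC2)nc1`) carries the entry "not determined" (no result reported) and so offers no number, and compound 3 (`Cn1cccc(-c2ccc(N(C(=O)NCc3ccccc3)[C@H]3CC[C@H](Nc4ccc(C#N)cn4)CC3)cc2)c1=O`) carries the entry "not determined" (no result reported) in the same way.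

On these data alone, compound 4 (`Cn1ccc(-c2ccc(N(C(=O)NCc3ccccc3)[C@H]3CC[C@H](Nc4ccc(C#N)cn4)CC3)cc2)cc1=O`) has not yet been measured in this assay and remains open. Its difference from compound 2 is a group of 8 heavy atoms (6 carbon, 1 nitrogen, 1 oxygen; one six-membered aromatic ring with 1 hetero atom) in place of a group of 6 heavy atoms (5 carbon, 1 nitrogen; one six-membered aromatic ring with 1 hetero atom), on an aromatic carbon on an aromatic carbon of a six-membered aromatic ring of carbon only, para to a large group.

Among the compounds with values here, no step between two measured compounds is available, so nothing calibrates this change. The expectation rests on the structural change alone and points downward, to a fall beyond the usual scatter, with wide uncertainty. The expected change is a 2.8-fold lower number from compound 2 to compound 4 (0.45 log units; beyond the scatter) on this estimate. For compound 4 the estimated value is 100 nm/s with an expected range from 30 nm/s to 260 nm/s as a working figure.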

Compound 4, apparent permeability: 247 nm/s
The estimate for compound 4 lay 2.5-fold (0.39 log units) below the measured number, within the range that was stated.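

In this assay the series gains its first readable step, which is a 1.1-fold lower number from compound 2 to compound 4 (0.05 log units; within the scatter). On an aromatic carbon of a six-membered aromatic ring of carbon only, para to a large group, pyridin-3-yl and the larger entering group with its double bond outside aromatic rings therefore cannot be told apart in this read-out, although this rests on one pair alone. The data at hand offer no measured explanation for this result.

The steps that would involve compound 1 or compound 3 cannot be read, so the pair gives no view of how the read-out responds to the bare ring of compound 1 or to the ring arrangement of compound 3. On these data alone, whether a carboxylic acid or an amine at this same place would stay within the scatter of compound 2 also remains open.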